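From a pentyl amide to a piperidine amide

The source may report more compounds than this note shows. Statements on the series, on what has been measured and on what is new or still open speak of the compounds shown alone.

In a functional assay on the whole organism (strain Wistar) for inhibition, with Rattus norvegicus as the target, read by paw edema, with stated times of 60 min and 1 h, at a dose of 100 mg/kg by the oral route (a higher number here means more inhibition at the dose given (going by the name of the read-out), a lower number less inhibition), compound 1 `CCCCNC(=O)CC1CCc2cc(OC)c(OC)cc21` gives 31.3%. Compound 2 `CCCCCNC(=O)CC1CCc2cc(OC)c(OC)cc21` gives 34.4%, and compound 3 `COc1cc2c(cc1OC)C(CC(=O)NC1CCCCC1)CC2` gives 50%. Compound 2 thus stands second highest of the three, close to compound 1 and further from compound 3: the step of a number 3.1 percentage points higher from compound 1 to compound 2 (within the scatter) is within the scatter, while a number 15.6 percentage points higher from compound 2 to compound 3 (beyond the scatter) is modest and beyond it. Compound 4 `COc1cc2c(cc1OC)C(CC(=O)N1CCCCC1)CC2` differs from compound 2 by piperidin-1-yl in place of pentylamino on a carbonyl carbon. The step from compound 2 to compound 3 bears on this change, as both bring a six-membered ring onto the amide-type nitrogen; a number 18.7 percentage points higher from compound 1 to compound 3 (beyond the scatter) points the same way. Among the measured compounds shown here, no measured step, however, removes the hydrogen-bond donor, so only a small rise is expected. Compound 4 is therefore expected to give about 39%, between 24% and 54%, a step of a number 4.6 percentage points higher from compound 2 to compound 4 (within the scatter) that is expected to stay within the scatter.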

Compound 4, a percentage reported as inhibition, in the whole organism at one dose (the size of the read-out at that dose, not a potency): 18.8%
Compound 4: middle estimate off by 20.2 percentage points, on the high side; the measured number lies below the stated range.
By their numbers in this assay, from the lowest: compound 4; then compounds 1 and 2 (each within the scatter of the next); then compound 3.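

In this assay, a six-membered ring at this place does not by itself raise the number: piperidin-1-yl on the carbonyl carbon lowers it against cyclohexylamino (a number 31.2 percentage points lower from compound 3 to compound 4 (beyond the scatter)), pentylamino (a number 15.6 percentage points lower from compound 2 to compound 4 (beyond the scatter)) and butylamino (a number 12.5 percentage points lower from compound 1 to compound 4 (beyond the scatter)). Pentylamino and piperidin-1-yl hold the same count of heavy atoms, so that count alone does not set the number here. Nothing at hand accounts for the fall.

As far as these compounds go, what stays open is whether the fall follows the loss of the amide hydrogen or the ring itself. A diethylamino group on the same carbonyl carbon, with no ring and no amide hydrogen, would help separate the two.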